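Cyclohexyl to cyclopentyl on a chalcone that sits at the limit

A few compounds are considered here, and "the series" means these few. Any claim that something is new, unique, unknown or untested is made for them only; others in the source may bear on it.

Compound 2, `O=C(/C=C/c1ccc(O)cc1)c1c(O)cccc1OCC1CCCCC1`, is the starting point. In a functional assay on HCT-15 cells (Homo sapiens) for antiproliferative activity, read by sulforhodamine B assay (on this read-out higher numbers stand for weaker inhibition of growth and lower numbers for stronger inhibition of growth), compound 2 gives > 30000 nM, which is a limit of the assay rather than a number. Compound 1, `CCCCCCOc1cccc(O)c1C(=O)/C=C/c1ccc(O)cc1`, carries a pentyl chain in the same place, and in this assay compound 1 gives > 30000 nM, again a limit. Compound 3, `CC(C)(C)CCOc1cccc(O)c1C(=O)/C=C/c1ccc(C(=O)O)cc1`, has a tert-butyl-bearing chain and a carboxylic acid on the distal ring; in this assay compound 3 gives 2170 nM. Among the compounds with values here, the one step between neighbours, a step that the two limits leave unreadable from compound 1 to compound 2, is unreadable because the limit of > 30000 nM in this assay, at which 2 of the 3 values shown sit, hides its size and direction.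

Compound 4, `O=C(/C=C/c1ccc(O)cc1)c1c(O)cccc1OCC1CCCC1`, arises from compound 2 by cyclopentyl in place of cyclohexyl on a saturated chain carbon bound to an oxygen on an aromatic ring. Within the data shown here, no measured step speaks to this change. Compound 2 gives only a limit in this assay, so the expectation for compound 4 can only be that it stays near that limit, with a number no higher from compound 2 to compound 4 (the limit leaves the size open) expected to be no step beyond the scatter. Compound 4 is therefore estimated at 30000 nM in this assay, within 8000 nM to 100000 nM.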

Compound 4, concentration for 50% growth inhibition: 3410 nM
Compound 4: the middle estimate sits 8.8-fold (0.94 log units) above what was measured; measured number outside the range, below it.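

In this assay, within the data shown here, the group on the saturated chain carbon bound to an oxygen on an aromatic ring can change the result, and the earlier compounds could not show this: going from cyclohexyl to cyclopentyl gives an at least 8.7-fold lower number from compound 2 to compound 4 (0.94 log units; beyond the scatter). Replacing the open pentyl chain with cyclopentyl at the same place gives an at least 8.7-fold lower number from compound 1 to compound 4 (0.94 log units; beyond the scatter). Among these compounds, of compound 1, compound 2 and compound 4, only compound 4 gives a number rather than a limit of the assay, so these are the first readable steps at this place.

The full size of both steps stays open because each starts from a limit: the limit of > 30000 nM in this assay, at which 2 of the 4 values shown sit. The compounds shown also leave open whether a cyclobutyl group, or a longer chain ending in cyclopentyl, would lower the number further at this place.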